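From Fluoro to Chloro on the Aromatic Ring

A few compounds are considered here, and "the series" means these few. Any claim that something is new, unique, unknown or untested is made for them only; others in the source may bear on it.

In a functional assay on NCI-H460 cells (Homo sapiens) for inhibition, read by MTT assay, with a stated time of 72 h (on this read-out higher numbers stand for weaker inhibition and lower numbers for stronger inhibition), compound 1 `COc1cc(NC(C)CCCNC(=O)Nc2cccc(Cl)c2)c2ncccc2c1` gives 37000 nM. Compound 2 `COc1cc(NC(C)CCCNC(=O)NNC(=O)Nc2ccc(F)cc2)c2ncccc2c1` reads > 100000 nM, which is a limit of the assay and not a number. Compound 3 `COc1cc(NC(C)CCCNC(=O)NNC(=O)Nc2cccc(F)c2)c2ncccc2c1` gives 50000 nM, and it stands level with compound 1 within the usual scatter, as a 1.4-fold higher number from compound 1 to compound 3 (0.13 log units; within the scatter) shows.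

Compound 4 `COc1cc(NC(C)CCCNC(=O)NNC(=O)Nc2cccc(Cl)c2)c2ncccc2c1` differs from compound 3 in one place: chloro in place of fluoro on an aromatic carbon. This puts chloro in place of fluoro on an aromatic carbon, meta to a large group.

For the measured compounds named here, no measured step makes this swap alone, so the evidence is indirect. Putting 3-fluorophenyl in place of 4-fluorophenyl gave an at least 2.0-fold lower number from compound 2 to compound 3 (0.30 log units; that floor lies within the scatter). Compound 1 already carries 3-chlorophenyl, and its value of 37000 nM lies close to that of compound 3, so no step beyond the scatter is expected in this assay. The expected change is a 1.2-fold lower number from compound 3 to compound 4 (0.08 log units; within the scatter). Compound 4 is estimated at 42000 nM, with an expected range of 18000 nM to 95000 nM.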

Compound 4, half-maximal inhibitory concentration: 32000 nM
Estimate against measurement, compound 4: 1.3-fold (0.12 log units) above; the range from low to high includes it.
By their numbers in this assay, from the lowest: compounds 4, 1 and 3 (each within the scatter of the next). At a limit, above all of these: compound 2.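

Swapping fluoro for chloro on this aromatic carbon gives a 1.6-fold lower number from compound 3 to compound 4 (0.19 log units; within the scatter), so in this assay the position accepts either halogen without a change that can be told from the scatter. With 3-chlorophenyl held fixed, adding the carbamoylamino link gives a 1.2-fold lower number from compound 1 to compound 4 (0.06 log units; within the scatter), which shows that this longer link also makes no readable difference when the halogen is the same. The only new step beyond the scatter is an at least 3.1-fold lower number from compound 2 to compound 4 (0.49 log units; beyond the scatter), but it starts from a limit of the assay and not a number, and it changes both the halogen and where it sits: the limit of > 100000 nM in this assay, at which 1 of the 4 values shown sits.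

Still open, as far as these compounds go, is whether an amine or a nitrile on this same aromatic carbon would move the number beyond the scatter. For the compounds shown here, also open is how a longer chain in place of the one these compounds share would read in this assay.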